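Heteroaryl sulfonamide swap: expectation for compound 4

The source may hold more compounds than are shown below. What is called first, only, known or untested is meant among the compounds shown, and "the series" means these compounds.

Three compounds share one core and differ only in the heteroaryl group on the sulfonamide nitrogen. Compound 1 `C=C1CC[C@@H]2[C@](C)(COC(C)=O)[C@H](OC(C)=O)CC[C@@]2(C)[C@H]1CC(Nc1ccc(S(=O)(=O)Nc2ccc(Cl)nn2)cc1)C1=CCOC1=O` reaches only the limit of the assay in a functional assay on Hs-578T cells (Homo sapiens) for inhibition, read by sulforhodamine B assay, with a stated time of 48 h (on this read-out lower numbers stand for stronger inhibition of growth and higher numbers for weaker inhibition of growth), giving > 100000 nM (the limit of > 100000 nM in this assay, at which 1 of the 3 values shown sits). Compound 2 `C=C1CC[C@@H]2[C@](C)(COC(C)=O)[C@H](OC(C)=O)CC[C@@]2(C)[C@H]1CC(Nc1ccc(S(=O)(=O)Nc2cc(C)on2)cc1)C1=CCOC1=O` gives 26700 nM in this assay. Compound 3 `C=C1CC[C@@H]2[C@](C)(COC(C)=O)[C@H](OC(C)=O)CC[C@@]2(C)[C@H]1CC(Nc1ccc(S(=O)(=O)Nc2ncccn2)cc1)C1=CCOC1=O` gives 24400 nM, the lowest of the two actual numbers, with compound 2 next to it within the scatter.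

The steps seen so far: an at least 3.7-fold lower number from compound 1 to compound 2 (0.57 log units; beyond the scatter) and an at least 4.0-fold lower number from compound 1 to compound 3 (0.61 log units; beyond the scatter) are both beyond the scatter, while a 1.1-fold lower number from compound 2 to compound 3 (0.04 log units; within the scatter) stays within it.

Compound 4 `C=C1CC[C@@H]2[C@](C)(COC(C)=O)[C@H](OC(C)=O)CC[C@@]2(C)[C@H]1CC(Nc1ccc(S(=O)(=O)Nc2nccs2)cc1)C1=CCOC1=O` carries the change (1,3-thiazol-2-yl in place of pyrimidin-2-yl on a sulfonamide nitrogen). The step bearing most directly on it is the exchange of one heteroaryl for another of the same kind as from compound 2 to compound 3, which stayed within the scatter; the larger steps from compound 1 involve the limit value and say little about the size of a swap between two measured heteroaryls. The step from compound 3 to compound 4 is therefore expected to be a 1.0-fold higher number from compound 3 to compound 4 (0.01 log units; within the scatter), that is, nothing beyond the scatter in this assay. Compound 4 is estimated to give 25000 nM, with a range from 9000 nM to 70000 nM.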

Compound 4, concentration for total growth inhibition: 60400 nM
Beside the measured number, compound 4's estimate is 2.4-fold (0.38 log units) below it, and the stated range covers the measured number.
By their numbers in this assay, from the lowest: compounds 3 and 2 (each within the scatter of the next); then compound 4. At a limit, above all of these: compound 1.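

On the sulfonamide nitrogen, a swap of one heteroaryl for another is not always neutral in this assay: there is a 2.5-fold higher number from compound 3 to compound 4 (0.39 log units; beyond the scatter) and a 2.3-fold higher number from compound 2 to compound 4 (0.35 log units; beyond the scatter), both beyond the scatter, whereas the earlier exchange between two measured heteroaryls stayed within it. Compound 4 therefore separates from compounds 2 and 3, which remain within the scatter of each other, so this position now distinguishes between heteroaryl groups by actual numbers and not only through a limit. The remaining comparison gives an at least 1.6-fold lower number from compound 1 to compound 4 (0.21 log units; that floor lies within the scatter), a floor that does not order the pair, and compound 1 stands at a limit of the assay: the limit of > 100000 nM in this assay, at which 1 of the 4 values shown sits.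

The pyrimidin-2-yl to 1,3-thiazol-2-yl change alters the ring size and brings in sulfur at once, so the compounds shown cannot assign the step to either difference. It also remains open how a plain phenyl or a methyl group on the sulfonamide nitrogen would read in this assay, since every group shown there is a heteroaryl.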